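Fluoro for methoxy on the benzylamino arm

The source may hold more compounds than are shown below. What is called first, only, known or untested is meant among the compounds shown, and "the series" means these compounds.

Of the compounds shown here, two have been measured so far. Compound 1 `CCN1CCN(CCCn2cnc3c(N4CCN(CC)CC4)nc(NC(=O)c4ccccc4)nc32)CC1` carries a benzoyl group on the amino nitrogen of the shared core; in an assay on HEK293 cells for antagonist activity at Toll-like receptor 9 (Homo sapiens), read by spectrophotometry (on this read-out higher numbers stand for weaker inhibition and lower numbers for stronger inhibition), compound 1 gives 340 nM. Compound 2 `CCN1CCN(CCCn2cnc3c(N4CCN(CC)CC4)nc(NCc4ccc(OC)cc4)nc32)CC1` carries a 4-methoxybenzyl group on that nitrogen instead; in this assay compound 2 gives 200 nM. The step of a 1.7-fold lower number from compound 1 to compound 2 (0.23 log units; within the scatter) is the only measured one, and it does not separate the two compounds beyond the scatter, so compound 2 stands next to compound 1 rather than apart from it.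

Compound 3 `CCN1CCN(CCCn2cnc3c(N4CCN(CC)CC4)nc(NCc4ccc(F)cc4)nc32)CC1` differs from compound 2 by fluoro in place of methoxy on an aromatic carbon. Going by the values given here, no measured step touches a change of this kind: the step from compound 1 to compound 2 exchanges the whole benzoyl group for a 4-methoxybenzyl group and says nothing about a methoxy-to-fluoro swap on the benzyl ring. With no evidence for a shift in either direction, the expected step is a 1.3-fold higher number from compound 2 to compound 3 (0.10 log units; within the scatter) in this assay. Compound 3 is therefore estimated at 250 nM in this assay, with a range from 90 nM to 700 nM.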

Compound 3, half-maximal inhibitory concentration: 470 nM
Beside the measured number, compound 3's estimate is 1.9-fold (0.27 log units) below it; measured number inside the range.
By their numbers in this assay, from the lowest: compounds 2, 1 and 3 (each within the scatter of the next, the first and the last beyond it).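

In this assay, going by these compounds alone, fluoro in place of methoxy on the benzyl ring gives the first step that lies beyond the scatter, modest though it is: the change from the 4-methoxybenzyl to the 4-fluorobenzyl group produces a 2.4-fold higher number from compound 2 to compound 3 (0.37 log units; beyond the scatter) on the read-out. A single small group on this aromatic carbon can therefore move the number measurably, which the earlier exchange of a whole benzoyl group did not show. The 4-fluorobenzyl group still does not separate from the benzoyl group on the same nitrogen, since a 1.4-fold higher number from compound 1 to compound 3 (0.14 log units; within the scatter) stays within the scatter, so only the 4-methoxybenzyl and 4-fluorobenzyl pair stands apart. No supporting measurement bears on why methoxy and fluoro differ here.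

As far as these compounds go, it remains open whether a chloro, a methyl or a hydroxyl group on this carbon, or a plain unsubstituted benzyl group, would read closer to the methoxy compound or to the fluoro compound. Also open, from the compounds shown here alone, is how an acetyl group or a longer phenethyl chain on the same nitrogen would compare with the benzoyl and benzyl groups.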